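Amino in Place of Azido: What Compound 4 Should Show

The source may report more compounds than this note shows. Statements on the series, on what has been measured and on what is new or still open speak of the compounds shown alone.

Measured so far in a functional assay (Homo sapiens) for inhibition of Nucleic Acid, tested at 100 uM; a lower number here means less inhibition, a higher number more inhibition at the concentration tested (going by the name of the read-out):
compound 1 `Clc1[nH]ccc2ncnc1-2` gives 6%
compound 2 `Sc1[nH]ccc2ncnc1-2` gives 26%
compound 3 `[N-]=[N+]=Nc1[nH]ccc2ncnc1-2` gives 20%

Compound 3 stands second highest of these three numbers. Its nearest neighbour is compound 2, and the step of a number 6 percentage points lower from compound 2 to compound 3 (within the scatter) lies within the scatter, so no order between the two is claimed. Its furthest neighbour is compound 1; the step of a number 14 percentage points higher from compound 1 to compound 3 (beyond the scatter) is beyond the scatter, as is a number 20 percentage points higher from compound 1 to compound 2 (beyond the scatter). Compound 4 `Nc1[nH]ccc2ncnc1-2` differs from compound 3 by amino in place of azido on an aromatic carbon. Among the measured compounds shown here, no measured step replaces azido by amino, so none bears directly on this change; the two steps that leave chloro were modest. One therefore expects no step beyond the scatter in this assay, and estimates for compound 4 a value of 16%, between 2% and 32%. The expected step is a number 4 percentage points lower from compound 3 to compound 4 (within the scatter).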

Compound 4, a percentage reported as inhibition, at one concentration (the size of the read-out at that concentration, not a potency): 60%
The estimate for compound 4 lay 44 percentage points below the measured number, and the stated range ends below it.
By their numbers in this assay, from the lowest: compound 1; then compounds 3 and 2 (each within the scatter of the next); then compound 4.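

Amino on this aromatic carbon stands apart in this assay: the change gives a number 40 percentage points higher from compound 3 to compound 4 (beyond the scatter) and a number 34 percentage points higher from compound 2 to compound 4 (beyond the scatter) and also a number 54 percentage points higher from compound 1 to compound 4 (beyond the scatter) with all three steps large. The steps among chloro, sulfanyl and azido were modest at most, so only now does this position show that a single change of group can move the number this far. Compound 4 is the highest of the four by this read-out.

As far as these compounds go, whether a methylamino or a hydroxyl group in this place would hold that level stays open. Nothing measured here accounts for the jump.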